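The compounds below may be only part of what the source reports. "The series", "measured", "known", "first", "only" and "open" are said of these compounds alone.

In an ADME assay on a cell-free system (plasma, Rattus norvegicus) for protein binding, compound 1 `CNc1nccc(N2CC[C@H](NC(=O)Nc3ccc(Cl)c(C(F)(F)F)c3)C2)n1` gives 99.7% and compound 2 `CNc1nccc(N2CC[C@H](NC(=O)Nc3ccc(OC(F)(F)F)cc3)C2)n1` gives 98.1%, while compound 3 `CCNc1nccc(N2CC[C@H](NC(=O)Nc3ccc(Cl)c(C(F)(F)F)c3)C2)n1` gives 99.9% and so has the smallest unbound fraction of the three. Compound 4 `O=C(Nc1ccc(Cl)c(C(F)(F)F)c1)N[C@H]1CCN(c2ccnc(NC3CC3)n2)C1` is still unmeasured and differs from compound 3 by a single change (cyclopropyl in place of ethyl on a nitrogen on an aromatic ring) with cyclopropyl in place of ethyl on a nitrogen on an aromatic ring.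

Within the data shown here, the only measured step on this nitrogen substituent, a 3.0-fold lower unbound fraction from compound 1 to compound 3 (0.48 log units; beyond the scatter) with methyl in place of hydrogen on a saturated chain carbon bound to a nitrogen on an aromatic ring, is modest, so a step of similar or smaller size is expected in this assay for the new change. Among the measured compounds shown here, no measured step replaces a chain with a ring, and compound 2 offers no step at this position, so the evidence is thin. The direction is uncertain, with a slight lean towards more free compound and no clear move beyond the scatter. The estimated step is a 2.0-fold higher unbound fraction from compound 3 to compound 4 (0.30 log units; within the scatter) and remains an expectation until measured. For compound 4 the estimated value is 99.8% with an expected range of 99.4% to 99.95% for the measurement.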

Compound 4, plasma protein binding: 99.9%
Compound 4: middle estimate off by 2.0-fold (0.30 log units) (unbound fraction), on the high side; low and high end bracket the measured number.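

In this assay, among these compounds, the three-membered ring of cyclopropyl takes the place of the ethyl chain on the nitrogen on an aromatic ring with no change at the digits printed from compound 3 to compound 4 (within the scatter) and so, unlike the earlier compounds, gives a first reading of a ring at this position on the chloro and trifluoromethyl-bearing series. Measured against the methyl substituent, cyclopropyl gives a 3.0-fold lower unbound fraction from compound 1 to compound 4 (0.48 log units; beyond the scatter) and this matches a 3.0-fold lower unbound fraction from compound 1 to compound 3 (0.48 log units; beyond the scatter) in size, so in these three compounds ethyl and cyclopropyl both stand apart from methyl while showing no difference from each other. Nothing available here accounts for the size of these steps or for the match between them.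

Still open is how this assay responds at this nitrogen to a longer chain or to a chain ending in an amine or a carboxylic acid, since the three substituents shown are all made of carbon only and carry no hydrogen-bond donors or acceptors. Also open, on these data alone, is whether the step from methyl to cyclopropyl is repeated in the trifluoromethoxy-bearing compound 2 at 98.1% where more of the compound is free and a step has more room to show in the printed digits.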